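Swapping chloro for fluoro on the pyridine ring

The source may report more compounds than this note shows. Statements on the series, on what has been measured and on what is new or still open speak of the compounds shown alone.

Compound 1 `Cn1c(COc2cccc(C(=O)O)c2)nc2ccc(Oc3ccc(Cl)cn3)cc21` and compound 2 `Cn1c(COc2cccc(C(=O)O)c2)nc2ccc(Oc3ccc(F)cn3)cc21` share one core and differ in a single group. In a physicochemical assay for lipophilicity, read by LC-MS, in phosphate buffer, measured as octanol-water partition, with a stated time of 30 min, at pH 7.4, tested at 200 mM (on this read-out lower numbers stand for lower lipophilicity and higher numbers for higher lipophilicity), compound 1 gives 1.2, and compound 2 gives 0.6. The change between them is fluoro in place of chloro on an aromatic carbon, and it produced a number 0.60 log units lower from compound 1 to compound 2 (beyond the scatter).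

Compound 3 `Cn1c(COc2cccc(C(=O)O)c2)nc2ccc(Oc3ncc(Cl)cc3Cl)cc21` carries a differently substituted ring on the oxygen of the shared core; it differs from compound 1 by chloro in place of hydrogen on an aromatic carbon. In this assay compound 3 gives 1.9, which stands as a number 0.70 log units higher from compound 1 to compound 3 (beyond the scatter) and as a number 1.30 log units higher from compound 2 to compound 3 (beyond the scatter), so it is the highest of the three numbers.

Compound 4 `Cn1c(COc2cccc(C(=O)O)c2)nc2ccc(Oc3ncc(Cl)cc3F)cc21` has not yet been measured. It differs from compound 3 by fluoro in place of chloro on an aromatic carbon. Within the data shown here, this is the same kind of change as the one from compound 1 to compound 2, but not the same: in compound 1 the site is para to a large group, whereas in compound 3 it is ortho to a large group and meta to a chloro group. Because the earlier swap gave a number 0.60 log units lower from compound 1 to compound 2 (beyond the scatter), a step of similar size is expected here. That step is estimated as a number 0.50 log units lower from compound 3 to compound 4 (beyond the scatter). In this assay compound 4 is therefore expected to give about 1.4, most likely between 1 and 1.8.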

Compound 4, distribution coefficient: 1.3
Compound 4: the middle estimate sits 0.10 log units above what was measured, within the range that was stated.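

In this assay, fluoro in place of chloro gave a number 0.60 log units lower from compound 3 to compound 4 (beyond the scatter) on the ring that carries a second chloro group, and the same swap on the ring without it gave a number 0.60 log units lower from compound 1 to compound 2 (beyond the scatter) as its counterpart, so in these two pairs the change kept its direction and size when the surroundings of the site differed. The neighbouring steps fit this reading: 5-chloro-3-fluoropyridin-2-yl in place of 5-fluoropyridin-2-yl gave a number 0.70 log units higher from compound 2 to compound 4 (beyond the scatter) as a clear step, while fluoro in place of hydrogen gave a number 0.10 log units higher from compound 1 to compound 4 (within the scatter) and so no readable change. Two matching pairs are not a rule, however: all four compounds share one core, so nothing here shows that the step would carry over to a different core, and nothing shown offers a reason for the match.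

The compounds shown leave open whether a nitrile or a trifluoromethyl group at the site ortho to a large group would read like fluoro or chloro in this assay on this core. They also leave open whether the fluoro-for-chloro step would keep its size if an amide or an amine stood in place of the carboxylic acid.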